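Oxygen-to-sulfur ring swap on a sulfonyl-linked chain

The compounds below may be only part of what the source reports. "The series", "measured", "known", "first", "only" and "open" are said of these compounds alone.

Compound 2 `COc1ccc(C2=NOC(c3ccc(C)cc3)C2S(=O)(=O)CC2=NCCO2)cc1` and compound 3 `COc1ccc(C2=NOC(c3ccc(C)cc3)C2S(=O)(=O)CC2=NCCS2)cc1` share one core and differ in a single place: a group of 5 heavy atoms (3 carbon, 1 nitrogen, 1 sulfur; one five-membered non-aromatic ring with 2 hetero atoms) in place of a group of 5 heavy atoms (3 carbon, 1 nitrogen, 1 oxygen; one five-membered non-aromatic ring with 2 hetero atoms), on a saturated chain carbon bound to a sulfonyl sulfur. In a functional assay, tested at 75 ug/mL (on this read-out lower numbers stand for a weaker effect and higher numbers for a stronger effect at the one concentration tested), compound 2 gives 66.6%, and compound 3 gives 49.7%. The change produces a number 16.9 percentage points lower from compound 2 to compound 3 (beyond the scatter).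

For the measured compounds named here, compound 1 `O=S(=O)(CC1=NCCO1)c1c(-c2ccccc2)nn(-c2ccccc2)c1-c1ccccc1` is built on a different core; how that core differs from the one of compound 2 is not broken down here. In this assay compound 1 gives 57.3%. Set against compound 2 and compound 3, the number for compound 1 lies within the usual scatter of each of them, so nothing is read from those gaps.

Compound 4 `O=S(=O)(CC1=NCCS1)c1c(-c2ccccc2)nn(-c2ccccc2)c1-c1ccccc1` has not been measured. It differs from compound 1 by a group of 5 heavy atoms (3 carbon, 1 nitrogen, 1 sulfur; one five-membered non-aromatic ring with 2 hetero atoms) in place of a group of 5 heavy atoms (3 carbon, 1 nitrogen, 1 oxygen; one five-membered non-aromatic ring with 2 hetero atoms), on a saturated chain carbon bound to a sulfonyl sulfur. The place is described in the same words as for the pair of compound 2 and compound 3, so this is the same change carried onto the core of compound 1.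

The expectation for compound 4 rests on one precedent only, on another core. Because that precedent is a number 16.9 percentage points lower from compound 2 to compound 3 (beyond the scatter), compound 4 is expected to show a step of a number 15.3 percentage points lower from compound 1 to compound 4 (beyond the scatter). With a single precedent and a different core, the range is kept wide. For compound 4 the estimate in this assay is 42%, expected to fall between 28% and 58%.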

Compound 4, a percentage reported as activity, at one concentration (the size of the read-out at that concentration, not a potency): "not active" (no number reported)
No number was reported for compound 4; no gap can be computed for the estimate.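

In this assay, for the compounds shown here, compound 4 is reported as not active, without a number, and no step from compound 1 to compound 4 can be read. The compounds shown leave open whether this ring swap on the core of compound 1 has a size comparable to a number 16.9 percentage points lower from compound 2 to compound 3 (beyond the scatter). Nothing measured here bears on the result.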